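A few compounds are considered here, and "the series" means these few. Any claim that something is new, unique, unknown or untested is made for them only; others in the source may bear on it.

Compound 2, `CC(C)(C)CN1CCC(NCCSC(c2ccc(F)cc2)c2ccc(F)cc2)CC1`, gives the lower of the two numbers recorded in an assay on membranes from Cortex for displacement of a labelled ligand from Sigma non-opioid intracellular receptor 1 (Cavia porcellus), read by scintillation counting, with a stated time of 120 min; on this read-out higher numbers stand for weaker inhibition and lower numbers for stronger inhibition: compound 2 gives 315 nM. Among the compounds with values here, its only neighbour is compound 1, `O=C(c1cc2ccccc2[nH]1)N1CCC(NCCSC(c2ccc(F)cc2)c2ccc(F)cc2)CC1`, which carries an indolylcarbonyl group on the same ring nitrogen; in this assay compound 1 gives 1130 nM. Compound 3, `O=C(c1ccccc1F)N1CCC(NCCSC(c2ccc(F)cc2)c2ccc(F)cc2)CC1`, has not yet been measured. It differs from compound 2 in one place: (2-fluorophenyl)carbonyl in place of neopentyl on an amine nitrogen in a ring. Within the data shown here, the one measured step that bears on this change is a 3.6-fold lower number from compound 1 to compound 2 (0.55 log units; beyond the scatter), where an aromatic carbonyl group on that nitrogen was exchanged for the neopentyl group and the number fell. Compound 3 reverses that kind of exchange, putting an aromatic carbonyl group back in place of neopentyl, so a rise of comparable size is expected, a 2.9-fold higher number from compound 2 to compound 3 (0.46 log units; beyond the scatter). Compound 3 is therefore estimated at 900 nM, within a range of 300 nM to 2800 nM.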

Compound 3, inhibition constant: 3.57 nM
For compound 3 the middle estimate is 250-fold (2.40 log units) above the measured one, outside the stated range (below it).
By their numbers in this assay, from the lowest: compound 3; then compound 2; then compound 1.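

In this assay, an aromatic carbonyl group on the ring nitrogen does not of itself raise the number: (2-fluorophenyl)carbonyl in place of neopentyl gives an 88-fold lower number from compound 2 to compound 3 (1.95 log units; beyond the scatter), the opposite direction to the earlier step. The group on the carbonyl carbon carries much of the outcome, as 2-fluorophenyl in place of 1H-indol-2-yl gives a 320-fold lower number from compound 1 to compound 3 (2.50 log units; beyond the scatter), which puts the two aromatic carbonyl groups on either side of neopentyl. Nothing available explains these steps.

The compounds shown leave open whether the fluorine of the 2-fluorophenyl group plays any part in this, which a plain phenyl on the carbonyl carbon would test. They also leave open whether the carbonyl itself is needed, which a benzyl group on the same nitrogen would test.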